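Swapping Fluorophenyl for Pyridin-4-yl: an Expected Step

The compounds below may be only part of what the source reports. "The series", "measured", "known", "first", "only" and "open" are said of these compounds alone.

Among the compounds with values here, compound 2 `O=c1cc(-c2ccc(F)cc2)oc2ccc(OCCCCCCN3CCC(O)CC3)cc12` is the better of the two compounds measured so far: in an assay on isolated protein (Cavia porcellus) with Sigma non-opioid intracellular receptor 1 (Homo sapiens) as the target, read by radioligand binding (on this read-out lower numbers stand for stronger inhibition and higher numbers for weaker inhibition), compound 2 gives 95 nM, the lowest of the two numbers. The nearest is compound 1 `O=c1cc(-c2cccnc2)oc2ccc(OCCCCCCN3CCC(O)CC3)cc12`, which in this assay gives 194 nM; the step of a 2.0-fold lower number from compound 1 to compound 2 (0.31 log units; beyond the scatter) lies beyond the usual scatter. Compound 3 `O=c1cc(-c2ccncc2)oc2ccc(OCCCCCCN3CCC(O)CC3)cc12` is not yet measured and differs from compound 2 by pyridin-4-yl in place of 4-fluorophenyl on an aromatic carbon. Within the data shown here, the one measured step that bears on it is the swap of pyridin-3-yl for 4-fluorophenyl from compound 1 to compound 2, which gave a modest gain; returning to a pyridyl ring, now pyridin-4-yl, has no exact measured counterpart, but the closest precedent points the other way. In this assay the expected step is a 2.1-fold higher number from compound 2 to compound 3 (0.32 log units; beyond the scatter). Compound 3 is therefore estimated at 200 nM, with a range from 90 nM to 450 nM.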

Compound 3, half-maximal inhibitory concentration: 159 nM
Beside the measured number, compound 3's estimate is 1.3-fold (0.10 log units) above it; low and high end bracket the measured number.
By their numbers in this assay, from the lowest: compounds 2, 3 and 1 (each within the scatter of the next, the first and the last beyond it).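

In this assay, the step of a 1.7-fold higher number from compound 2 to compound 3 (0.22 log units; within the scatter) shows that pyridin-4-yl, whose ring carries a nitrogen and counts one hydrogen-bond acceptor, cannot be told apart from 4-fluorophenyl at this position. The step of a 1.2-fold lower number from compound 1 to compound 3 (0.09 log units; within the scatter) shows that the two pyridyl groups cannot be told apart either, so compound 3 sits within the scatter of both earlier compounds, and only the gap between compound 1 and compound 2 remains beyond it. No measurement at hand explains these numbers.

Still open, going by these compounds, is how a plain phenyl ring, or a phenyl ring carrying an amine or a carboxylic acid, would compare at this position. Also open, on these data alone, is whether these small differences would hold with a longer chain in place of the one shared here.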